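Aryl group change next to the ring sulfur

The compounds below may be only part of what the source reports. "The series", "measured", "known", "first", "only" and "open" are said of these compounds alone.

Measured so far in an assay on CHO cells for displacement of a labelled ligand from adenosine receptor A3 (Homo sapiens), read by scintillation counting, tested at 10 uM; on this read-out lower numbers stand for less inhibition and higher numbers for more inhibition at the one concentration tested (going by the name of the read-out):
compound 1 `CC(C)(C)Cc1csc(N)c1C(=O)c1ccc(Cl)cc1` gives 5%
compound 2 `CC(C)(C)Cc1c(-c2ccncc2)sc(N)c1C(=O)c1ccc(Cl)cc1` gives 6%
compound 3 `COc1cccc(-c2sc(N)c(C(=O)c3ccc(Cl)cc3)c2CC(C)(C)C)c1` gives 1%

Compound 3 has the lowest of the three numbers in this assay, yet both of its steps stay within the scatter: a number 4 percentage points lower from compound 1 to compound 3 (within the scatter) and a number 5 percentage points lower from compound 2 to compound 3 (within the scatter). No order among the three can be read from this.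

Compound 4 `Cc1ccc(-c2sc(N)c(C(=O)c3ccc(Cl)cc3)c2CC(C)(C)C)cc1` differs from compound 3 by 4-methylphenyl in place of 3-methoxyphenyl on an aromatic carbon. Within the data shown here, the steps that bear on this position are the three already seen at the same aromatic carbon: a number 1 percentage points higher from compound 1 to compound 2 (within the scatter), a number 4 percentage points lower from compound 1 to compound 3 (within the scatter) and a number 5 percentage points lower from compound 2 to compound 3 (within the scatter). Hydrogen, pyridin-4-yl and 3-methoxyphenyl at this carbon all leave the read-out in the same low band, so a further aryl group there is expected to do the same. The expected step for compound 4 is a number 2 percentage points higher from compound 3 to compound 4 (within the scatter), none beyond the scatter. Compound 4 is therefore estimated at 3% in this assay, with a range from 0% to 12%.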

Compound 4, a percentage reported as inhibition, at one concentration (the size of the read-out at that concentration, not a potency): 1%
The estimate for compound 4 lay 2 percentage points above the measured number; measured number inside the range.
By their numbers in this assay, from the lowest: compounds 3, 4, 1 and 2 (each within the scatter of the next).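

In this assay, 4-methylphenyl in place of 3-methoxyphenyl on the aromatic carbon next to the ring sulfur gives no change at the digits printed from compound 3 to compound 4 (within the scatter), so this exchange, which leaves the entering aryl group with no hydrogen-bond acceptor, does not move the read-out beyond the scatter. The comparisons with the other groups at this carbon agree, with a number 5 percentage points lower from compound 2 to compound 4 (within the scatter) and a number 4 percentage points lower from compound 1 to compound 4 (within the scatter), so hydrogen, pyridin-4-yl, 3-methoxyphenyl and 4-methylphenyl cannot be told apart here. No measured evidence bears on this result.

As far as these compounds go, whether a non-aryl group at this carbon, such as an amine, a carboxylic acid or a longer chain, would shift the read-out stays open. From the compounds shown here alone, the neopentyl, amino and (4-chlorophenyl)carbonyl groups are constant across these compounds, so the effect of changing them also stays open.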